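A few compounds are considered here, and "the series" means these few. Any claim that something is new, unique, unknown or untested is made for them only; others in the source may bear on it.

Of the compounds shown here, two have so far been measured in an assay on isolated protein for inhibition of protein kinase C delta type (Homo sapiens), read by TR-FRET, with a stated time of 2 h; a lower number here means a stronger inhibitor, a higher number a weaker inhibitor. Compound 1 `CN(C)C(=O)[C@H]1CC[C@@H](Nc2cc(NCc3cnccc3C(F)(F)F)ncc2C#N)CC1` gives 1800 nM in this assay. Compound 2 `CC1(C)[C@H](O)C[C@H]1Nc1nc(NCc2cnccc2C(F)(F)F)ncc1C#N` gives 4500 nM in this assay, the higher of the two numbers, and its gap to compound 1 lies beyond the usual scatter. Compound 3 `CC1(C)[C@@H](Nc2nc(NCc3cnccc3C(F)(F)F)ncc2C#N)C[C@@H]1O` has not yet been measured. Compared with compound 2, (the two compounds have the same atoms and bonds and differ only in configuration as drawn: 2 of 2 stereo elements differ (all stereocentres are inverted: mirror images); a stereocentre at a saturated ring carbon is drawn R in compound 2 and S in compound 3; a stereocentre at a saturated ring carbon is drawn R in compound 2 and S in compound 3). For the measured compounds named here, no measured pair in this set separates mirror images from one another, so there is no observed step to show how large such a change can be here, nor in which direction it runs. The expectation is that the two mirror images may differ in this assay by more than the scatter, with no basis for choosing one direction over the other. The step of a 1.3-fold lower number from compound 2 to compound 3 (0.11 log units; within the scatter) is therefore estimated as small in the middle, with a wide range on both sides. For compound 3 the estimated value in this assay is 3500 nM, with a range from 600 nM to 20000 nM.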

Compound 3, half-maximal inhibitory concentration: 2000 nM
For compound 3 the middle estimate is 1.8-fold (0.24 log units) above the measured one; the range from low to high includes it.
By their numbers in this assay, from the lowest: compounds 1 and 3 (each within the scatter of the next); then compound 2.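

The mirror-image pair gives this set its first measured step of configuration alone, and in this assay that step is a 2.3-fold lower number from compound 2 to compound 3 (0.35 log units; beyond the scatter), modest in size but large enough to show that the configuration drawn at these two ring carbons registers in the read-out. The step can be attributed to configuration alone because no atom or bond changes between the two structures: the fact that compounds 2 and 3 differ only in the configuration as drawn The direction is also now known for this pair, with the form drawn S at both stereocentres giving the lower number, although both stereocentres invert together, so the step belongs to the two of them jointly and not to either one.

The compounds shown leave open how much of the step each stereocentre carries by itself, which only a form with a single stereocentre inverted could settle. They also leave open whether the same direction would hold if an amine or a methoxy group stood in place of the hydroxyl on this ring.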